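The source may report more compounds than this note shows. Statements on the series, on what has been measured and on what is new or still open speak of the compounds shown alone.

Compound 2 `Cc1ccccc1NC(=O)CSc1nncnc1-c1ccccc1Cl` gives the highest number of the three compounds measured in an ADME assay on MT4 cells (Homo sapiens) for cytotoxicity, read by MTT assay (a lower number here means that less compound is tolerated, a higher number that more compound is tolerated), namely 142000 nM. Compound 1 `O=C(CSc1nncnc1-c1ccccc1Cl)c1ccc(Cl)c(Cl)c1` gives 33000 nM in this assay, and compound 3 `CC(=O)c1ccc(NC(=O)CSc2nncnc2-c2ccccc2Cl)c(Br)c1` gives 34000 nM. Among the measured compounds shown here, the one measured step that changes a single place is a 4.3-fold higher number from compound 1 to compound 2 (0.63 log units; beyond the scatter), so replacing the 3,4-dichlorophenyl ketone end with an anilide end moved the number upward by a modest amount. Compound 4 `O=C(CSc1nncnc1-c1ccccc1Cl)Nc1cccnc1Cl` keeps the anilide arrangement of compound 2 and differs in one place: 2-chloropyridin-3-yl in place of 2-methylphenyl on an amide-type nitrogen. For the measured compounds named here, no measured step swaps one ring for another on the amide-type nitrogen, so the step from compound 1 to compound 2 bears on it only loosely, and compound 3, the other anilide, sits a good deal lower than compound 2 without a single-place step connecting them. The expectation for compound 4 is therefore a small downward step, a 2.0-fold lower number from compound 2 to compound 4 (0.31 log units; beyond the scatter), with wide uncertainty. Compound 4 is estimated at 70000 nM, within a range from 25000 nM to 200000 nM.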

Compound 4, half-maximal cytotoxic concentration: 167000 nM
Beside the measured number, compound 4's estimate is 2.4-fold (0.38 log units) below it; the range from low to high includes it.
By their numbers in this assay, from the lowest: compounds 1 and 3 (each within the scatter of the next); then compounds 2 and 4 (each within the scatter of the next).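

In this assay, changing the ring on the amide-type nitrogen gives a 1.2-fold higher number from compound 2 to compound 4 (0.07 log units; within the scatter), so 2-chloropyridin-3-yl and 2-methylphenyl cannot be told apart at this position, although the entering ring carries a ring nitrogen and a chlorine. Against the 3,4-dichlorophenyl end of compound 1, the new end gives a 5.1-fold higher number from compound 1 to compound 4 (0.70 log units; beyond the scatter), much like the step already seen for the end of compound 2. No measurement at hand explains why the ring change leaves the number within the scatter.

As far as these compounds go, it remains open what the ring nitrogen and the chlorine each contribute, which 2-chlorophenyl or 2-methylpyridin-3-yl on the same nitrogen would separate. Also open, from the compounds shown here alone, is whether the number holds with a ring bearing a carboxylic acid or an amine, or with a plain butyl chain instead of a ring.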